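A few compounds are considered here, and "the series" means these few. Any claim that something is new, unique, unknown or untested is made for them only; others in the source may bear on it.

The measured compounds:
compound 1 `COc1ccc(Cn2c(=O)n(C3OC(CO)[C@@H](O)[C@H]3O)c3nc(N)nc(O)c32)cc1` gives 2 uM
compound 2 `CN(C)CCCn1c(=O)n(C2OC(CO)[C@@H](O)[C@H]2O)c2nc(N)nc(O)c21` gives 820 uM
compound 3 `Cn1c(=O)n(C2OC(CI)[C@@H](O)[C@H]2O)c2nc(N)nc(O)c21` gives 52 uM

All three share one core and were tested in a functional assay with Mus musculus as the target; a lower number here means that less compound is needed, a higher number that more compound is needed for the effect. Compound 3 stands second highest of the three numbers: compound 2 gives a higher value, compound 1 a lower one. Compound 4 `Cn1c(=O)n(C2OC(CO)[C@@H](O)[C@H]2O)c2nc(N)nc(O)c21` differs from compound 3 by hydroxy in place of iodo on a saturated chain carbon bound to a saturated ring carbon. The only measured step, a 410-fold higher number from compound 1 to compound 2 (2.61 log units; beyond the scatter), concerns a group on a saturated chain carbon bound to an aromatic nitrogen, a different place, so no measured step bears on the present change, and nothing among these compounds shows what exchanging iodo for hydroxy does. Lacking such guidance, only a small step is expected, a 1.5-fold higher number from compound 3 to compound 4 (0.19 log units; within the scatter), with no sure direction. Compound 4 is therefore estimated at 80 uM, between 15 uM and 400 uM.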

Compound 4, concentration for half-maximal effect: 120 uM
Beside the measured number, compound 4's estimate is 1.5-fold (0.18 log units) below it; the range from low to high includes it.
By their numbers in this assay, from the lowest: compound 1; then compound 3; then compound 4; then compound 2.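

In this assay, hydroxy in place of iodo on a saturated chain carbon bound to a saturated ring carbon gives a 2.3-fold higher number from compound 3 to compound 4 (0.36 log units; beyond the scatter), so this position responds to the change, though modestly. Among the compounds shown here, compound 4 also links the earlier compounds on the saturated chain carbon bound to an aromatic nitrogen: losing 2-(dimethylamino)ethyl gives a 6.8-fold lower number from compound 2 to compound 4 (0.83 log units; beyond the scatter), while losing 4-methoxyphenyl gives a 60-fold higher number from compound 1 to compound 4 (1.78 log units; beyond the scatter), so these two groups move the number in opposite directions. Nothing measured here explains either effect. On these data alone, whether an amine or a carboxylic acid at the iodo and hydroxy position would give a lower number than either group stays open, as does whether the iodo-to-hydroxy step keeps its size with 4-methoxyphenyl on the core.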